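Adding a Methyl Group Where the Numbers Already Sit at a Limit

This account rests on a few compounds, and the source may have more. Where it says the series, first, only, none or still open, it means among the compounds named here.

Measured compounds in an ADME assay on HEL cells (Homo sapiens) for cytotoxicity, read by cell counting, with a stated time of 3 days; on this read-out lower numbers stand for higher toxicity in this test and higher numbers for lower toxicity in this test:
- compound 1, `O=c1[nH]c(=O)n([C@H]2C[C@H](O)[C@@H](CO)O2)cc1-c1cn(-c2ccccc2)nn1`, gives 270000 nM
- compound 2, `O=c1[nH]c(=O)n([C@H]2C[C@H](O)[C@@H](CO)O2)cc1-c1cn(-c2cc(F)cc(F)c2)nn1`, gives 220000 nM
- compound 3, `CC(C)c1ccc(-n2cc(-c3cn([C@H]4C[C@H](O)[C@@H](CO)O4)c(=O)[nH]c3=O)nn2)cc1`, gives only > 240000 nM, which is a limit of the assay rather than a number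

Across these three, the read-out hardly moves. The step of a 1.2-fold lower number from compound 1 to compound 2 (0.09 log units; within the scatter) stays within the scatter. The step that the limit leaves unreadable from compound 1 to compound 3 cannot be read because of the limit of > 240000 nM in this assay, at which 1 of the 3 values shown sits. The step of an at least 1.0-fold higher number from compound 2 to compound 3 (0.03 log units; that floor lies within the scatter) is likewise only a floor. Compound 3 therefore stands at the limit, among the least toxic on the numbers shown, without a measured value of its own.

Compound 4, `CC(C)(C)c1ccc(-n2cc(-c3cn([C@H]4C[C@H](O)[C@@H](CO)O4)c(=O)[nH]c3=O)nn2)cc1`, differs from compound 3 by methyl in place of hydrogen on a saturated chain carbon bound to an aromatic carbon and two saturated chain carbons. Going by the values given here, no measured step speaks to this change directly, and the steps that surround compound 3 show no movement beyond the scatter. For this assay, the step that the limit leaves unreadable from compound 3 to compound 4 is expected to be none beyond the scatter, with a fair chance that compound 4 again returns only a limit. Compound 4 is expected at 250000 nM, in the range 120000 nM to 500000 nM.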

Compound 4, minimum cytotoxic concentration: 230000 nM
Compound 4: middle estimate off by 1.1-fold (0.04 log units), on the high side; the range from low to high includes it.
By their numbers in this assay, from the lowest: compounds 2, 4 and 1 (each within the scatter of the next).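

Unlike compound 3, compound 4 has a measured number in this assay, so the 4-(tert-butyl)phenyl group can be compared directly with the groups on the aromatic nitrogen of the other measured compounds. The step of a 1.0-fold higher number from compound 2 to compound 4 (0.02 log units; within the scatter) and the step of a 1.2-fold lower number from compound 1 to compound 4 (0.07 log units; within the scatter) both stay within the scatter, so phenyl, 3,5-difluorophenyl and 4-(tert-butyl)phenyl do not separate on this read-out. The added methyl itself can be read only as an at least 1.0-fold lower number from compound 3 to compound 4 (0.01 log units; that floor lies within the scatter), which is a floor rather than a measured size, because compound 3 has no number of its own: the limit of > 240000 nM in this assay, at which 1 of the 4 values shown sits.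

As far as these compounds go, it remains open what an amine or a carboxylic acid on the phenyl ring would do to this read-out. From the compounds shown here alone, it also remains open whether any group at this place can move the number beyond the scatter.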